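The compounds below may be only part of what the source reports. "The series", "measured", "known", "first", "only" and "open" are said of these compounds alone.

Compounds measured so far:

Compound 1, `CC[C@@H]1/C=C(\C)C[C@H](C)C[C@H](OC)[C@H]2O[C@@](O)(C(=O)C(=O)N3CCCC[C@H]3C(=O)O[C@H](/C(C)=C/[C@@H]3CC[C@@H](Oc4ccccc4)[C@H](OC)C3)[C@H](C)[C@@H](O)CC1=O)[C@H](C)C[C@@H]2OC`, gives 5.4 nM in a functional assay on cells for inhibition, with Murine T-cell line (Mus musculus) as the target; a higher number here means a weaker inhibitor, a lower number a stronger inhibitor.
Compound 2, `CC[C@@H]1/C=C(\C)C[C@H](C)C[C@H](OC)[C@H]2O[C@@](O)(C(=O)C(=O)N3CCCC[C@H]3C(=O)O[C@H](/C(C)=C/[C@@H]3CC[C@@H](Oc4cccc(O)c4)[C@H](OC)C3)[C@H](C)[C@@H](O)CC1=O)[C@H](C)C[C@@H]2OC`, gives 1.7 nM in this assay.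
Compound 3, `CC[C@@H]1/C=C(\C)C[C@H](C)C[C@H](OC)[C@H]2O[C@@](O)(C(=O)C(=O)N3CCCC[C@H]3C(=O)O[C@H](/C(C)=C/[C@@H]3CC[C@@H](Oc4ccc(N(C)C)cc4)[C@H](OC)C3)[C@H](C)[C@@H](O)CC1=O)[C@H](C)C[C@@H]2OC`, gives 1.1 nM in this assay.

Compound 3 has the lowest number of the three in this assay. Its nearest neighbour is compound 2, and the gap between them is within the scatter, so the two cannot be ordered; compound 1 lies furthest away, as a 4.9-fold lower number from compound 1 to compound 3 (0.69 log units; beyond the scatter) shows, a step beyond the scatter. Compound 4, `CC[C@@H]1/C=C(\C)C[C@H](C)C[C@H](OC)[C@H]2O[C@@](O)(C(=O)C(=O)N3CCCC[C@H]3C(=O)O[C@H](/C(C)=C/[C@@H]3CC[C@@H](Oc4ccc(SC)cc4)[C@H](OC)C3)[C@H](C)[C@@H](O)CC1=O)[C@H](C)C[C@@H]2OC`, is not yet measured. It differs from compound 3 in one place: methylsulfanyl in place of dimethylamino on an aromatic carbon.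

Going by the values given here, no measured step exchanges one substituent for another at that aromatic carbon of the phenoxy group while both are present, so the change has no direct precedent. Among the compounds with values here, the steps that bear on it are a 3.2-fold lower number from compound 1 to compound 2 (0.50 log units; beyond the scatter) and a 4.9-fold lower number from compound 1 to compound 3 (0.69 log units; beyond the scatter), which show that adding either group to the unsubstituted ring of compound 1 lowers the number modestly, and a 1.5-fold lower number from compound 2 to compound 3 (0.19 log units; within the scatter), which shows that the two substituted compounds sit within the scatter of each other. The methylsulfanyl group keeps the ring substituted, so compound 4 is expected to remain near compound 3, with at most a small rise, a 1.6-fold higher number from compound 3 to compound 4 (0.21 log units; within the scatter), as the expectation. The estimate for compound 4 in this assay is 1.8 nM, in a range from 0.7 nM to 5 nM.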

Compound 4, half-maximal inhibitory concentration: 2.6 nM
The estimate for compound 4 lay 1.4-fold (0.16 log units) below the measured number; measured number inside the range.
By their numbers in this assay, from the lowest: compounds 3, 2 and 4 (each within the scatter of the next, the first and the last beyond it); then compound 1.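

In this assay, methylsulfanyl at this aromatic carbon, para to a large group, still lowers the number relative to the unsubstituted ring of compound 1 (a 2.1-fold lower number from compound 1 to compound 4 (0.32 log units; beyond the scatter)), so all three substituted compounds now stand beyond the scatter from compound 1, and none among those shown goes against this. The exchange of one substituent for another at this carbon can now be read directly, and it is not neutral: the number rises modestly when methylsulfanyl replaces dimethylamino (a 2.4-fold higher number from compound 3 to compound 4 (0.37 log units; beyond the scatter)), although compound 4 cannot be ordered against the hydroxy-bearing compound 2, since that step lies within the scatter (a 1.5-fold higher number from compound 2 to compound 4 (0.18 log units; within the scatter)). Nothing available accounts for the difference between dimethylamino and methylsulfanyl.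

The compounds shown leave open whether a carboxylic acid, a primary amine or a longer chain such as butylsulfanyl at this carbon would keep the number as low as dimethylamino does. They also leave open whether dimethylamino and methylsulfanyl would give the same result on any other carbon of the ring.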